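Loss of the chain phenyl in a quinolinylmethoxy aryl acid series

A few compounds are considered here, and "the series" means these few. Any claim that something is new, unique, unknown or untested is made for them only; others in the source may bear on it.

Measured compounds:
- compound 1, `O=C(O)CCC(Cc1ccc(OCc2ccc3ccccc3n2)cc1)c1ccccc1`: 31 nM
- compound 2, `CC(CCCC(=O)O)c1cccc(OCc2ccc3ccccc3n2)c1`: 90 nM
- compound 3, `O=C(O)CCC(Cc1cccc(OCc2ccc3ccccc3n2)c1)c1ccccc1`: 52 nM

Three aryl alkanoic acids sharing the same quinolinylmethoxy-substituted aromatic core have been examined in an assay on membranes from lung (Cavia porcellus) for binding affinity to cysteinyl leukotriene receptor (Homo sapiens); a higher number here means a weaker inhibitor, a lower number a stronger inhibitor. Compound 1 gives 31 nM and so stands at the lowest number of the three. Compound 3, which gives 52 nM, lies within the usual scatter of compound 1, so the two cannot be told apart. Compound 2, which gives 90 nM, lies beyond the scatter from compound 1, at a higher number. Compound 2 and compound 3 differ from compound 1 and from each other in more than one place, so no single structural step can be read from their values.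

Compound 4, `CC(CCC(=O)O)Cc1ccc(OCc2ccc3ccccc3n2)cc1`, differs from compound 1 in one place: methyl in place of phenyl on a saturated chain carbon bound to two saturated chain carbons. Among the measured compounds shown here, no measured pair isolates this change. For the measured compounds named here, compound 2, the one measured compound that also carries a methyl on a saturated chain carbon, gives 90 nM, but its chain and its substitution on the core are not those of compound 4, so it can only hint at direction.

The phenyl removed is the larger part of the side chain, and the expectation is that compound 4 loses some affinity, with a step from compound 1 of a 3.9-fold higher number from compound 1 to compound 4 (0.59 log units; beyond the scatter) in this assay, beyond the scatter but not large. Compound 4 is therefore estimated at 120 nM in this assay, with a range from 40 nM to 400 nM.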

Compound 4, inhibition constant: 43 nM
Beside the measured number, compound 4's estimate is 2.8-fold (0.45 log units) above it; the range from low to high includes it.
By their numbers in this assay, from the lowest: compounds 1, 4, 3 and 2 (each within the scatter of the next, the first and the last beyond it).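

In this assay, among the compounds shown here, the exchange gives a 1.4-fold higher number from compound 1 to compound 4 (0.14 log units; within the scatter), so the two compounds cannot be told apart, and this is the first pair to isolate a single change. At this position, on a saturated chain carbon bound to two saturated chain carbons, phenyl with its 6 heavy atoms and its six-membered aromatic ring can give way to methyl with its 1 heavy atom, and the number stays within the scatter. On the core of compound 1, then, the ring on this chain carbon is not required for a number of this size, although this rests on a single pair, and nothing measured here offers a reason for the result.

The compounds shown leave open whether a bare hydrogen, an ethyl group or a cyclohexyl group at this carbon would also stay within the scatter of compound 1. They also leave open whether the same exchange would behave alike on the core of compound 3, and whether a longer chain or an amide in place of the carboxylic acid would be tolerated.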